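The source may report more compounds than this note shows. Statements on the series, on what has been measured and on what is new or still open speak of the compounds shown alone.

Compound 1 `CCOC(=O)c1c(-c2cccc(OC)c2)[nH]c2cc(C(F)(F)F)ccc2c1=O` gives > 21500 nM, which is a limit of the assay rather than a number.
Compound 2 `CCOC(=O)c1c(-c2cccc(Cl)c2)[nH]c2cc(C(F)(F)F)ccc2c1=O` gives > 21500 nM, also only a limit.
Compound 3 `CCOC(=O)c1c(-c2cccc(-c3ccccc3)c2)[nH]c2cc(Cl)c(Cl)cc2c1=O` gives > 21500 nM, again only a limit.

All three values come from an ADME assay on BJ cells (Homo sapiens) for cytotoxicity, read by luminescence, with a stated time of 72 h; on this read-out higher numbers stand for an effect only at larger amounts of compound and lower numbers for an effect already at smaller amounts. Going from compound 2 to compound 1 the change is methoxy in place of chloro on an aromatic carbon; the step that the two limits leave unreadable from compound 2 to compound 1 cannot be read because of the limit of > 21500 nM in this assay, at which 3 of the 3 values shown sit. The cores of compound 2 and compound 3 differ as well, but that difference is not broken down here. Compound 4 `CCOC(=O)c1c(-c2cccc(-c3ccccc3)c2)[nH]c2cc(OC)c(Cl)cc2c1=O` has not been measured yet; it arises from compound 3 by methoxy in place of chloro on an aromatic carbon, the same kind of change as before, though here the place is part of a fused or bridged system of two rings, ortho to a chloro group, meta to a fused ring and para to a fused ring. Given that (the limit of > 21500 nM in this assay, at which 3 of the 3 values shown sit), the step that the limit leaves unreadable from compound 3 to compound 4 is expected to be small. Compound 4 is estimated at 30000 nM, between 12000 nM and 90000 nM, and most likely it will again be reported only as a limit.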

Compound 4, half-maximal effective concentration: > 21500 nM
Compound 4 gave a limit, no number; the forecaster's own chance of this, stated with the estimate: 80%; the middle value does not contradict the limit.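

The step from compound 3 to compound 4 cannot be read, because both values are only limits: the limit of > 21500 nM in this assay, at which 4 of the 4 values shown sit. The compounds shown leave open at what concentration any of them would show an effect in this assay, and whether methoxy in place of chloro changes it.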